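From Methyl to Phenyl in a Growth Inhibitor

This account rests on a few compounds, and the source may have more. Where it says the series, first, only, none or still open, it means among the compounds named here.

Going by the values given here, only two compounds have been measured so far in a functional assay on HL-60 cells (Homo sapiens) for inhibition; a higher number here means a weaker inhibitor of growth, a lower number a stronger inhibitor of growth. There, compound 1 `C=C(C)C(=O)c1ccc(OCc2nc(-c3ccccc3)no2)cc1C` gives 6700 nM, while compound 2 `C=C(C)C(=O)c1ccc(OCc2nc(C)no2)c(C)c1C` gives 3200 nM. Compound 2 therefore has the lower number of the pair and is the stronger inhibitor of growth, and the gap between the two lies beyond the usual scatter.

The next compound to be tested is compound 3 `C=C(C)C(=O)c1ccc(OCc2nc(-c3ccccc3)no2)c(C)c1C`. It keeps the rest of compound 2 but has phenyl in place of methyl on an aromatic carbon of the five-membered aromatic ring with 2 nitrogen and 1 oxygen: phenyl in place of methyl on an aromatic carbon.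

Among the compounds with values here, compound 1 also carries phenyl at that carbon, but it differs from compound 2 in more than one place, so no measured step isolates this swap. Even so, the higher number of compound 1, 6700 nM, points to a small rise in this assay, close to the scatter. The expected change is a 1.3-fold higher number from compound 2 to compound 3 (0.12 log units; within the scatter). For compound 3, the estimated value is 4200 nM, with a likely range of 1700 nM to 10000 nM.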

Compound 3, concentration for 50% growth inhibition: 3500 nM
The estimate for compound 3 lay 1.2-fold (0.08 log units) above the measured number; the range from low to high includes it.
By their numbers in this assay, from the lowest: compounds 2, 3 and 1 (each within the scatter of the next, the first and the last beyond it).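

In this assay, putting phenyl in place of methyl on the aromatic carbon between two ring nitrogen atoms gives a 1.1-fold higher number from compound 2 to compound 3 (0.04 log units; within the scatter) and so adds a whole six-membered aromatic ring at this position with no change that can be told from scatter. The second step, methyl in place of hydrogen on an aromatic carbon, gives a 1.9-fold lower number from compound 1 to compound 3 (0.28 log units; within the scatter) and also stays within the scatter, so the gap between compound 1 and compound 2 is not matched by either single change on its own. No measured evidence here accounts for these small steps.

The phenyl and methyl groups at this position carry no hydrogen-bond donors or acceptors and no net charge, so the compounds shown leave open how a group such as an amine or a carboxylic acid would behave there. They also leave open whether a longer chain or a phenyl ring bearing further groups would keep the number in the same range or move it beyond the scatter.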